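The source may report more compounds than this note shows. Statements on the series, on what has been measured and on what is new or still open speak of the compounds shown alone.

Working notes on the furanyl-bearing series of compound 1 `CCOC(=O)c1cnc(NC2CCCC2)n2nc(-c3ccco3)nc12` and its congeners, all run in an assay on CHO cells for displacement of a labelled ligand from adenosine receptor A1 (Homo sapiens); a lower number here means a stronger inhibitor, a higher number a weaker inhibitor.

Compound 1 gives 34.4 nM in this assay. Compound 2 `CNc1ncc(C(=O)O)c2nc(-c3ccco3)nn12` carries the free carboxylic acid and a methylamino group where compound 1 has the ethyl ester and the cyclopentylamino group; the two differ in two places, so their values can only be set side by side. For compound 2 this assay reports only the limit of > 100000 nM, not a number, and compound 2 is therefore placed by the line the limit of > 100000 nM in this assay, at which 1 of the 2 values shown sits, rather than by a value of its own.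

Compound 3 `O=C(O)c1cnc(NCc2ccc(F)cc2)n2nc(-c3ccco3)nc12` keeps the acid of compound 2 and changes (4-fluorophenyl in place of hydrogen on a saturated chain carbon bound to a nitrogen on an aromatic ring). Since compound 2 sits at a limit, the size of the step cannot be judged from a measured pair; the expectation is a move in the stronger direction, large enough to leave the limit but not to approach compound 1.

Compound 3 is expected to give about 20000 nM in this assay, estimated between 2000 nM and 100000 nM. The step this implies, an at least 5.0-fold lower number from compound 2 to compound 3 (0.69 log units; beyond the scatter), is itself only an estimate.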

Compound 3, inhibition constant: > 100000 nM
Compound 3: no number, only a limit; the forecaster's own chance of this, stated with the estimate: 40%; at least 5.0-fold (0.69 log units) between middle value and limit.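

In this assay compound 3 gives only a limit, > 100000 nM, not a number. No step from compound 2 to compound 3 can be read, because both stand at a limit: the limit of > 100000 nM in this assay, at which 2 of the 3 values shown sit.

The compounds shown leave open whether 4-fluorophenyl in place of hydrogen shifts the inhibition constant at all while the free carboxylic acid stays.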